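Halogenated ring on the nitrogen of compound 1

The compounds below may be only part of what the source reports. "The series", "measured", "known", "first", "only" and "open" are said of these compounds alone.

Compound 1 `COc1cc(N(CC2CC2)c2ccccc2)cnc1C(=O)[C@H]1C[C@@H]1C(=O)O` is tested in an assay on isolated protein for inhibition of leukotriene C4 synthase (Homo sapiens), read by LC-MS, with stated times of 45 min and 20 min (a lower number here means a stronger inhibitor, a higher number a weaker inhibitor), where compound 1 gives 1640 nM. Going by the values given here, this is the only number in hand: compound 2 `COc1cc(N(CC2CC2)c2ccc(Cl)c3ccccc23)cnc1C(=O)CCCC(=O)O` was included but in this assay compound 2 gives "not determined" (no result reported), with no result reported. Compound 3 `COc1cc(N(CC2CC2)c2ccc(F)c(Cl)c2)cnc1C(=O)[C@H]1C[C@@H]1C(=O)O` differs from compound 1 by 3-chloro-4-fluorophenyl in place of phenyl on a nitrogen on an aromatic ring. Among the compounds with values here, no measured pair shows what this change does. The expected step is a 2.3-fold lower number from compound 1 to compound 3 (0.37 log units; beyond the scatter), a modest move toward stronger inhibition that could still sit within the scatter. In this assay compound 3 is expected to give 700 nM, within a range from 250 nM to 2500 nM.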

Compound 3, half-maximal inhibitory concentration: 42.3 nM
Estimate against measurement, compound 3: 17-fold (1.22 log units) above; measured number outside the range, below it.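

In this assay, going by these compounds alone, the ring on the nitrogen proves to be a sensitive position: 3-chloro-4-fluorophenyl in place of phenyl gives a 39-fold lower number from compound 1 to compound 3 (1.59 log units; beyond the scatter) and this large step is the first sign that adding atoms to this ring can strengthen inhibition. Going by these compounds, the two halogens enter together, so the share of the chlorine and of the fluorine stays open. Whether 3-chlorophenyl, 4-fluorophenyl or a ring bearing a nitrile would give a similar step is also unknown. Nothing at hand gives a cause for the size of this step.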